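Five-membered aromatic ring swap from compound 2 to compound 3

The source may report more compounds than this note shows. Statements on the series, on what has been measured and on what is new or still open speak of the compounds shown alone.

In a physicochemical assay for solubility, in phosphate buffer, with a stated time of 18 h (on this read-out lower numbers stand for lower solubility and higher numbers for higher solubility), compound 1 (`CC(C)(C)c1nc(-c2ccccc2)c2c(N)c(C#N)c(N)nc2n1`) gives 4000 nM and compound 2 (`Cc1c[nH]c(-c2nc(C(C)(C)C)nc3nc(N)c(C#N)c(N)c23)n1`) gives 5000 nM within the scatter of each other. For the measured compounds named here, the only measured step is a 1.3-fold higher number from compound 1 to compound 2 (0.10 log units; within the scatter) and it exchanges one aromatic group for another. The move to compound 3 (`CC(C)(C)c1nc(-c2nc(CO)cs2)c2c(N)c(C#N)c(N)nc2n1`) is 4-(hydroxymethyl)-1,3-thiazol-2-yl in place of 4-methyl-1H-imidazol-2-yl on an aromatic carbon in the same place. Going by the values given here, no measured compound carries a thiazole or a hydroxymethyl group, so that single step is a thin guide. No change beyond the scatter is expected in this assay on this basis. The expected move is a 1.3-fold lower number from compound 2 to compound 3 (0.10 log units; within the scatter) and stays inside that scatter. Compound 3 is estimated at 4000 nM (range 1500 nM to 10000 nM).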

Compound 3, solubility: < 1000 nM
Compound 3: a limit, no number (the forecaster's own chance of this, stated with the estimate: 10%); middle value at least 4.0-fold (0.60 log units) from the limit.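

In this assay compound 3 gives < 1000 nM, a limit of the assay and not a number. This position is not indifferent to the group it carries: 4-(hydroxymethyl)-1,3-thiazol-2-yl brings an at least 5.0-fold lower number from compound 2 to compound 3 (0.69 log units; beyond the scatter) and an at least 4.0-fold lower number from compound 1 to compound 3 (0.60 log units; beyond the scatter), whereas the earlier exchange gave only a 1.3-fold higher number from compound 1 to compound 2 (0.10 log units; within the scatter). How far the number falls remains unfixed: the limit of < 1000 nM in this assay, at which 1 of the 3 values shown sits.

The thiazole ring and the hydroxymethyl group enter together, so the compounds shown do not separate their contributions. Going by these compounds, whether an aminomethyl group in place of hydroxymethyl on the same thiazole would give a different reading remains open.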